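A Second Cyclohexyl Group on the Shared Core

The source may report more compounds than this note shows. Statements on the series, on what has been measured and on what is new or still open speak of the compounds shown alone.

Of the compounds shown here, three have been tested in a functional assay on A2780 cells (Homo sapiens) for antiproliferative activity; a higher number here means a weaker inhibitor of growth, a lower number a stronger inhibitor of growth. Compound 1 `CC(C)CC1OCCC(Cl)=C1[Si](C)(C)C` gives 66000 nM. Compound 2 `C[C@H]1CC(Cl)=C([Si](C)(C)C)[C@@H](C2CCCCC2)O1` gives 32000 nM, the lowest number of the three. Compound 3 `C[C@H]1CC(Cl)=C[C@@H](C2CCCCC2)O1` gives 38000 nM; the step of a 1.2-fold higher number from compound 2 to compound 3 (0.07 log units; within the scatter) leaves compound 2 and compound 3 indistinguishable, whereas compound 1 lies beyond the scatter from compound 2 but differs from it in more than one place, so those two values show only that gap.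

Compound 4 `C[Si](C)(C)C1=C(Cl)C[C@H](C2CCCCC2)O[C@@H]1C1CCCCC1` has not yet been measured. It differs from compound 2 by cyclohexyl in place of methyl on a saturated ring carbon, so that the saturated carbon next to the ring oxygen now carries a cyclohexyl group. Going by the values given here, no measured step touches this position: the only single-point step known, from compound 2 to compound 3, alters the group of 4 heavy atoms on a double-bonded ring carbon instead. With no direct guidance, compound 4 is expected to stay close to compound 2, with a 1.3-fold lower number from compound 2 to compound 4 (0.11 log units; within the scatter) as the likely step and no change beyond the scatter. The estimate for compound 4 in this assay is 25000 nM, within a range from 8000 nM to 80000 nM.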

Compound 4, concentration for total growth inhibition: 46000 nM
Compound 4: the middle estimate sits 1.8-fold (0.26 log units) below what was measured, and the stated range covers the measured number.
By their numbers in this assay, from the lowest: compounds 2, 3, 4 and 1 (each within the scatter of the next, the first and the last beyond it).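

Going by these compounds alone, this is the first single change at the saturated ring carbon next to the ring oxygen, since the earlier step touched only a double-bonded ring carbon. In this assay, cyclohexyl in place of methyl gives a 1.4-fold higher number from compound 2 to compound 4 (0.16 log units; within the scatter), so this exchange leaves the number indistinguishable from the original. No measurement available here explains why this large change in size has no clear effect on the number. Still open, on these data alone, is whether a group of a different kind at this carbon, such as an amine or a carboxylic acid, would shift the number beyond the scatter. A plain hydrogen or a longer open chain there would also show whether this carbon's substituent matters at all for growth inhibition.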